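The compounds below may be only part of what the source reports. "The series", "measured", "known", "first", "only" and "open" are said of these compounds alone.

Compound 1 `Cc1ccc2oc(=O)c(-c3ccc(Br)nn3)cc2c1` is one of three close relatives, each carrying a bromo group on a six-membered aromatic ring with 2 nitrogen attached to a shared core. In an assay on cells for inhibition of Amine oxidase [flavin-containing] B (Homo sapiens), read by fluorescence and Amplex Red, with a stated time of 15 min (a higher number here means a weaker inhibitor, a lower number a stronger inhibitor), compound 1 gives 2160 nM, the highest number of the three. Compound 2 `Cc1ccc2cc(-c3ccc(Br)nn3)c(=O)oc2c1` gives 750 nM, and compound 3 `COc1ccc2oc(=O)c(-c3ccc(Br)nn3)cc2c1` gives 560 nM. Within the data shown here, the single measured step in the set, a 3.9-fold lower number from compound 1 to compound 3 (0.59 log units; beyond the scatter), concerns the core itself, where methoxy takes the place of methyl. Compound 4 `COc1ccc(-c2cc3cc(C)ccc3oc2=O)nn1` differs from compound 1 on the other ring instead: methoxy in place of bromo on an aromatic carbon. Among the measured compounds shown here, no measured step touches a change on that ring, so the step from compound 1 to compound 3 offers no guide to the size or direction of this one. The change is small in atoms, and in the absence of any bearing step the number for compound 4 is expected to stay close to that of compound 1. Compound 4 is therefore estimated to give 2000 nM, within a range of 600 nM to 6500 nM. The expected step, a 1.1-fold lower number from compound 1 to compound 4 (0.03 log units; within the scatter), is thus estimated to lie within the scatter, with its direction left open.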

Compound 4, half-maximal inhibitory concentration: 17600 nM
Compound 4: middle estimate off by 8.8-fold (0.94 log units), on the low side; measured number outside the range, above it.
By their numbers in this assay, from the lowest: compounds 3 and 2 (each within the scatter of the next); then compound 1; then compound 4.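

In this assay the swap of bromo for methoxy gives an 8.1-fold higher number from compound 1 to compound 4 (0.91 log units; beyond the scatter), so this aromatic carbon on the ring with two nitrogens is sensitive to the group it carries, and bromo is the better of the two groups here. Methoxy on the core, in place of methyl, went the other way, with a 3.9-fold lower number from compound 1 to compound 3 (0.59 log units; beyond the scatter), so among these compounds the outcome of adding a methoxy depends on where it sits and what it replaces. No available evidence explains the weaker inhibition seen with methoxy on this ring.

A chloro group, a methyl group or an amine at this position would help show whether bromo helps or methoxy harms. From the compounds shown here alone, whether the same swap has a similar effect on the cores of compound 2 and compound 3 also remains open.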